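A Swap on the Sulfonyl Sulfur and Clearance

This account rests on a few compounds, and the source may have more. Where it says the series, first, only, none or still open, it means among the compounds named here.

Measured so far in an ADME assay on microsomes (Homo sapiens) for metabolic stability; on this read-out lower numbers stand for slow clearance and higher numbers for fast clearance:
- compound 1 `CNC(=O)[C@@H]1CCCN1S(=O)(=O)c1ccc(Cl)c(COc2cccc3c(-n4ccnc4)cc(C)nc23)c1Cl`: 33.3 mL/min/kg
- compound 2 `CNC(=O)[C@@H]1CCCN1S(=O)(=O)c1cccc(COc2cccc3c(C(F)(F)F)cc(C)nc23)c1`: 50 mL/min/kg
- compound 3 `Cc1cc(C(F)(F)F)c2cccc(OCc3c(Cl)ccc(S(=O)(=O)N4CCC[C@H]4C(=O)O)c3Cl)c2n1`: 8.33 mL/min/kg

Compound 3 has the lowest number of the three, and compound 1 and compound 2 both stand higher by more than the usual scatter of repeated measurements.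

The next compound, compound 4 `Cc1cc(C(F)(F)F)c2cccc(OCc3c(Cl)ccc(S(=O)(=O)N4CC[C@@H](N(C)C)C4)c3Cl)c2n1`, differs from compound 3 in one place, on a sulfonyl sulfur: 3-(dimethylamino)pyrrolidin-1-yl in place of 2-carboxypyrrolidin-1-yl on a sulfonyl sulfur. In words, 3-(dimethylamino)pyrrolidin-1-yl stands in place of 2-carboxypyrrolidin-1-yl, and the rest of compound 3 stays the same.

Among the compounds with values here, no two measured compounds differ in only one place, so this swap has no direct precedent. Within the data shown here, the only guide is indirect. Among the measured compounds, only compound 3 carries 2-carboxypyrrolidin-1-yl, and it gives 8.33 mL/min/kg. Without that group, compound 1 gives 33.3 mL/min/kg and compound 2 gives 50 mL/min/kg. Both also differ from compound 3 elsewhere, so the hint is weak, and the range must stay wide.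

The expected change in this assay is a 3.4-fold higher number from compound 3 to compound 4 (0.53 log units; beyond the scatter), a rise beyond the scatter. The estimate for compound 4 is 28 mL/min/kg, with an expected range of 13 mL/min/kg to 55 mL/min/kg.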

Compound 4, clearance: 167 mL/min/kg
Beside the measured number, compound 4's estimate is 6.0-fold (0.78 log units) below it, outside the stated range (above it).
By their numbers in this assay, from the lowest: compound 3; then compounds 1 and 2 (each within the scatter of the next); then compound 4.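

In this assay, the group on the sulfonyl sulfur proves to matter a great deal: with the rest of the molecule unchanged, 3-(dimethylamino)pyrrolidin-1-yl in place of 2-carboxypyrrolidin-1-yl gives a 20-fold higher number from compound 3 to compound 4 (1.30 log units; beyond the scatter). Within the data shown here, the earlier compounds could not show this directly, since no two of them differed in one place only, so this is the first clean reading of this position. It also shows that size alone does not settle the number here, as both groups have 8 heavy atoms and a five-membered non-aromatic ring, yet they lie far apart in clearance, and no measurement at hand accounts for the rise.

The compounds shown leave open how much of the rise comes from losing the carboxylic acid and how much comes from gaining the dimethylamino group, as the swap does both at once. A plain pyrrolidin-1-yl with no side group on the same sulfonyl sulfur would help separate the two, and a primary amide in place of the carboxylic acid would show whether a different group there behaves like either one.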